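Urea to amide: compound 2 leads on to compound 3

The source may report more compounds than this note shows. Statements on the series, on what has been measured and on what is new or still open speak of the compounds shown alone.

Compound 2 `COc1cc(Cl)cc(-c2nn(-c3cccc(NC(=O)Nc4cccc(C(F)(F)F)c4)c3)cc2-c2ccncc2)c1` was examined in a functional assay on UACC-62 cells (Homo sapiens) for inhibition, read by sulforhodamine B assay, with a stated time of 48 h, tested at 0.1 uM (a lower number here means a stronger effect, a higher number a weaker effect of the compound at the concentration tested), and compound 2 gives 96%. Going by the values given here, its only measured neighbour is compound 1 `COc1cc(Cl)cc(-c2nn(-c3cccc(NC(=O)Nc4ccc(Cl)c(Cl)c4)c3)cc2-c2ccncc2)c1`, which in this assay gives 97%; the pair is joined by a number 1 percentage points lower from compound 1 to compound 2 (within the scatter), so the two numbers stand together within the scatter. Compound 2 therefore sits, on the numbers available, at a level that tells of little effect at the concentration tested.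

The new compound 3 `COc1cc(Cl)cc(-c2nn(-c3cccc(NC(=O)c4cccc(C(F)(F)F)c4)c3)cc2-c2ccncc2)c1` departs from compound 2 by 3-(trifluoromethyl)phenyl in place of (3-(trifluoromethyl)phenyl)amino on a carbonyl carbon; the amide-type nitrogen and its attached aryl ring remain, and the carbonyl carbon now carries the 3-(trifluoromethyl)phenyl directly. No measured step of this kind exists among the compounds shown. Among the compounds with values here, the one step that is known, a number 1 percentage points lower from compound 1 to compound 2 (within the scatter), concerns a change on the other side of the carbonyl and was within the scatter, so it offers no guidance on direction.

Without a matching precedent, compound 3 is expected to give 94% in this assay, with a range of 82% to 104%. The expected step of a number 2 percentage points lower from compound 2 to compound 3 (within the scatter) is estimated not to exceed the scatter.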

Compound 3, a percentage reported as activity, at one concentration (the size of the read-out at that concentration, not a potency): 94%
The estimate for compound 3 equals the measured number at the digits printed; low and high end bracket the measured number.
By their numbers in this assay, from the lowest: compounds 3, 2 and 1 (each within the scatter of the next).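

In this assay, replacing (3-(trifluoromethyl)phenyl)amino with 3-(trifluoromethyl)phenyl on the carbonyl carbon removes the amino nitrogen and its hydrogen-bond donor, and the step is a number 2 percentage points lower from compound 2 to compound 3 (within the scatter). The comparison with the dichlorinated urea, in which 3-(trifluoromethyl)phenyl takes the place of (3,4-dichlorophenyl)amino, gives a number 3 percentage points lower from compound 1 to compound 3 (within the scatter), so the earlier finding that a change of aryl group left the reading within the scatter now extends to a change in the link itself, with all three compounds remaining at a level that tells of little effect at the concentration tested. No measurement is available that would account for this result.

Going by these compounds, since all three readings come from a single concentration and sit close together, it remains open whether the urea and the amide would separate at other concentrations, and this flat reading cannot show whether the amino nitrogen matters for activity. Also open, on these data alone, is how the reading would respond to a sulfonyl group in place of the carbonyl, a methylene between the carbonyl and the ring, or a piperazine on the 3-(trifluoromethyl)phenyl ring.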